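Shortening the ethoxy group of compound 2 to methoxy

The compounds below may be only part of what the source reports. "The series", "measured", "known", "first", "only" and "open" are said of these compounds alone.

Compound 1 `COCC1=C(C(=O)OC)C(c2cc(F)c(F)cc2F)N(C(=O)NCCCN2CCN(c3ccccc3C(N)=O)CC2)C(=O)N1`: 130 nM
Compound 2 `CCOc1ccccc1N1CCN(CCCNC(=O)N2C(=O)NC(C)=C(C(=O)OC)C2c2ccc(F)c(F)c2)CC1`: 8.8 nM
Compound 3 `CC(=O)C1=C(C)NC(=O)N(C(=O)NCCCN2CCN(c3ccccc3C(N)=O)CC2)C1c1ccc(F)c(F)c1`: 170 nM

Of the compounds shown here, three have been measured in an assay on liver for binding affinity to Alpha-1B adrenergic receptor (Homo sapiens), using microsomes; on this read-out lower numbers stand for stronger inhibition and higher numbers for weaker inhibition. Compound 2 gives the lowest number of the three with 8.8 nM. Compound 1, the nearest of the other two, gives 130 nM, a gap that lies beyond the usual scatter, and compound 3 gives 170 nM, also beyond the scatter. Compound 2 is therefore the strongest binder among the three measured.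

Compound 4 `COC(=O)C1=C(C)NC(=O)N(C(=O)NCCCN2CCN(c3ccccc3OC)CC2)C1c1ccc(F)c(F)c1` has not yet been measured. It differs from compound 2 in one place only: hydrogen in place of methyl on a saturated chain carbon bound to an oxygen on an aromatic ring. The rest of the molecule, from the difluorophenyl-bearing core through the urea and the propyl linker to the aryl piperazine, is unchanged.

Among the compounds with values here, no measured pair in this set shows the effect of such a change, so there is nothing here to say how large a step to expect. A single carbon removed from an alkoxy group is a small change, and the step from compound 2 to compound 4 in this assay is expected to be small, possibly none beyond the scatter, in either direction: a 1.0-fold higher number from compound 2 to compound 4 (0.01 log units; within the scatter). Compound 4 is therefore estimated at 9 nM, with a range from 3 nM to 27 nM.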

Compound 4, inhibition constant: 18 nM
Beside the measured number, compound 4's estimate is 2.0-fold (0.30 log units) below it, and the stated range covers the measured number.
By their numbers in this assay, from the lowest: compound 2; then compound 4; then compounds 1 and 3 (each within the scatter of the next).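

In this assay, going from 2-ethoxyphenyl to 2-methoxyphenyl gives a 2.0-fold higher number from compound 2 to compound 4 (0.31 log units; beyond the scatter). Within the data shown here, this is the first reading in the set of a change in one place, and it shows that this position responds to the removal of a single carbon from the chain on the aromatic oxygen: the step is modest, but it goes towards weaker binding rather than vanishing into the scatter. Of the two groups compared here, ethoxy gives the lower number on the shared core, but nothing available accounts for the direction or size of this step.

A single pair cannot show whether the number keeps falling as the chain grows, so a longer chain such as propoxy, a branched isopropoxy, or a hydroxyl group in place of the alkoxy group could each give a different answer at this position. As far as these compounds go, it also remains open whether the step from ethoxy to methoxy would have the same size with other substituents on the difluorophenyl ring or with an ethyl ester in place of the methyl ester.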